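From compound 2 to compound 3: one more fluoro

A few compounds are considered here, and "the series" means these few. Any claim that something is new, unique, unknown or untested is made for them only; others in the source may bear on it.

Measured in a physicochemical assay for acid dissociation, read by spectrophotometry, in phosphate buffer, at pH 4.3, tested at 0.1 mM:
Compound 1 `[N-]=[N+]=Nc1cc(B(O)O)c(F)cc1F`: 6.27
Compound 2 `[N-]=[N+]=Nc1ccc(F)c(B(O)O)c1`: 6.87

Of the two measured compounds, compound 2 stands highest, and compound 1 is the lower. Compound 3 `[N-]=[N+]=Nc1cc(F)c(F)c(B(O)O)c1` is not yet measured. It carries fluoro in place of hydrogen on an aromatic carbon, ortho to a fluoro group and meta to an azido group (fluoro in place of hydrogen on an aromatic carbon). Within the data shown here, one measured step bears on this change: a number 0.60 log units higher from compound 1 to compound 2 (beyond the scatter), which is the reverse swap, hydrogen in place of fluoro, made elsewhere on the core. A modest step downward of similar size is therefore expected in this assay, estimated as a number 0.67 log units lower from compound 2 to compound 3 (beyond the scatter). For compound 3 the expected value is 6.2, with an estimated range from 5.8 to 6.6.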

Compound 3, acid dissociation constant: 6.04
Beside the measured number, compound 3's estimate is 0.16 log units above it; measured number inside the range.
By their numbers in this assay, from the lowest: compounds 3 and 1 (each within the scatter of the next); then compound 2.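

In this assay the fluoro added ortho to a fluoro group and meta to an azido group gives a number 0.83 log units lower from compound 2 to compound 3 (beyond the scatter) at this position. The earlier step, a number 0.60 log units higher from compound 1 to compound 2 (beyond the scatter) with hydrogen in place of fluoro, came from another place on the core, so fluoro goes with the lower number at two places among these compounds. No measurement shown accounts for either step. From the compounds shown here alone, what remains open is whether a methoxy group or an amine at this position would shift the number in the same direction, or whether this behaviour is particular to fluoro.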